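Series notes: aryl substitution beside the methoxy group

The source may report more compounds than this note shows. Statements on the series, on what has been measured and on what is new or still open speak of the compounds shown alone.

compound 1 `CCOc1ccc(-n2cnc3cnc(-c4ccc(F)cc4C)cc32)cc1`: 19 nM
compound 2 `COc1ccc(-n2cnc3cnc(-c4ccc(F)cc4C)cc32)cc1F`: 10 nM

In a functional assay on HL-60 cells (Homo sapiens) for activation, read by flow cytometry, with a stated time of 4 days (on this read-out lower numbers stand for an effect already at smaller amounts and higher numbers for an effect only at larger amounts of compound), compound 2 gives 10 nM, the lower of the two numbers; compound 1 gives 19 nM, and the gap between them is within the scatter, so no order between the two is claimed. Compound 3 `COc1ccc(-n2cnc3cnc(-c4ccc(F)cc4C)cc32)cc1C(C)C` is not yet measured. It differs from compound 2 by isopropyl in place of fluoro on an aromatic carbon. Within the data shown here, no measured pair shows this change, so nothing in the data fixes its size or direction. A modest step, if any, is expected; the estimated step from compound 2 to compound 3 is a 2.5-fold higher number from compound 2 to compound 3 (0.40 log units; beyond the scatter). Compound 3 is expected to give about 25 nM in this assay, between 8 nM and 80 nM.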

Compound 3, half-maximal effective concentration: > 10000 nM
Compound 3 was reported as a limit (the forecaster's own chance of this, stated with the estimate: 5%); middle value at least 400-fold (2.60 log units) away from the limit.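

Compared with compounds 1 and 2, which differ in more than one place, this single change isolates the aromatic carbon ortho to a methoxy group and shows that the activity depends strongly on the group held there: isopropyl in place of fluoro gives an at least 1000-fold higher number from compound 2 to compound 3 (3.00 log units; beyond the scatter) in this assay. Compound 3 is reported only as a limit, so the full size of this step stays unread: the limit of > 10000 nM in this assay, at which 1 of the 3 values shown sits.

Only fluoro and isopropyl are compared on this carbon. From the compounds shown here alone, how a methyl group, an ethyl group or an amine would read there remains open.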